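The compounds below may be only part of what the source reports. "The series", "measured", "known", "first", "only" and "open" are said of these compounds alone.

Two members of this series have been run in an assay on isolated protein for inhibition of thyroid hormone receptor beta (Homo sapiens), read by fluorescence polarization; on this read-out lower numbers stand for stronger inhibition and higher numbers for weaker inhibition. Compound 1 `Cc1ccc(N2CCN(C(=O)C3CCN(C(=O)c4ccc(S(C)(=O)=O)c([N+](=O)[O-])c4)CC3)CC2)cc1` gives only a limit of this assay, > 60000 nM, not a number. Compound 2 `CC(C)N(C(=O)CCNC(=O)c1ccc(S(C)(=O)=O)c([N+](=O)[O-])c1)C(C)C` likewise gives only a limit, > 60000 nM. Both readings share (the limit of > 60000 nM in this assay, at which 2 of the 2 values shown sit), so compound 2 stands nowhere distinguishable within the set. Compound 3 `CC1CCN(C(=O)CCNC(=O)c2ccc(S(C)(=O)=O)c([N+](=O)[O-])c2)CC1` has not been measured. Compared with compound 2, it carries 4-methylpiperidin-1-yl in place of diisopropylamino on a carbonyl carbon. For the measured compounds named here, with no measured step in hand, no shift beyond the scatter is expected from compound 2 to compound 3, estimated as a step that the limit leaves unreadable from compound 2 to compound 3. Compound 3 is estimated at 80000 nM, with a range of 30000 nM to 200000 nM, most likely again reported only as a limit.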

Compound 3, half-maximal inhibitory concentration: > 60000 nM
Compound 3 gave a limit, no number; the forecaster's own chance of this, stated with the estimate: 85%; the middle value is on the limit's open side.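

In this assay, compound 2 and compound 3 both give only limits, not numbers, so no step can be read between them. The compounds shown leave open whether any member of this series gives a number in this assay.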